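A few compounds are considered here, and "the series" means these few. Any claim that something is new, unique, unknown or untested is made for them only; others in the source may bear on it.

Measured so far in an ADME assay on microsomes from liver (Rattus norvegicus) for metabolic stability; on this read-out lower numbers stand for slow clearance and higher numbers for fast clearance:
- compound 1 `CNc1nc(NC2(C#N)CCCCC2)nc(N(C)C)n1` gives 276 mL/min/kg
- compound 2 `CCC(C)(C#N)Nc1nc(NC)nc(-n2cncn2)n1` gives 32 mL/min/kg
- compound 3 `C#CC(CC)(CC)Nc1nc(NC)nc(-n2cncn2)n1` gives 22 mL/min/kg

Compound 1 has the highest number of the three, beyond the scatter from both of the others. Still to be measured is compound 4 `CNc1nc(C#N)nc(NC2(C#N)CCCCC2)n1`, which has cyano in place of dimethylamino on an aromatic carbon, with cyano in place of dimethylamino on an aromatic carbon as the full difference. For the measured compounds named here, the only measured step, a 1.5-fold lower number from compound 2 to compound 3 (0.16 log units; within the scatter), lies within the scatter and concerns a group on a nitrogen, so it does not size this change. A lower number is still expected, since dimethylamino is absent from both compound 2 at 32 mL/min/kg and compound 3 at 22 mL/min/kg in the same place. Going by the values given here, both also differ from compound 1 in the group on a nitrogen, so this support is loose and no measured step isolates the change. The expected change in this assay is a 3.1-fold lower number from compound 1 to compound 4 (0.49 log units; beyond the scatter) as a rough estimate. For compound 4 the estimated value is 90 mL/min/kg with an expected range from 30 mL/min/kg to 270 mL/min/kg in these notes.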

Compound 4, clearance: 122 mL/min/kg
Estimate against measurement, compound 4: 1.4-fold (0.13 log units) below; the measured number falls inside the stated range.
By their numbers in this assay, from the lowest: compounds 3 and 2 (each within the scatter of the next); then compound 4; then compound 1.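

Working on the aromatic carbon between two ring nitrogen atoms, the change from dimethylamino to cyano can now be sized on its own in this assay: a 2.3-fold lower number from compound 1 to compound 4 (0.35 log units; beyond the scatter). This position therefore affects the read-out with the methylamino group and the group of 9 heavy atoms held constant, but the step is modest and compound 4 still gives 122 mL/min/kg in this assay. Nothing available on the compounds shown bears on the reason for this step.

On these data alone, how a methoxy group, a chlorine atom or a primary amine at this position would compare with cyano and dimethylamino remains open. As far as these compounds go, it is also open whether the same change would give a step of similar size with a 1-cyano-1-methylpropyl or 1,1-diethylprop-2-yn-1-yl group on the nitrogen.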